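A few compounds are considered here, and "the series" means these few. Any claim that something is new, unique, unknown or untested is made for them only; others in the source may bear on it.

Measured so far in an ADME assay on BSC-1 cells (Cercopithecidae) for cytotoxicity; on this read-out higher numbers stand for weaker inhibition and lower numbers for stronger inhibition:
- Compound 1 `Nc1ncnc2c1ccn2COCCO` — > 100000 nM, a limit of the assay
- Compound 2 `NC(=NO)c1cn(COCCO)c2ncnc(N)c12` — > 100000 nM, a limit of the assay

Compound 2 stands at the limit of this assay. Its value, > 100000 nM, is a limit and not a number. Compound 1 also sits at a limit, giving > 100000 nM. Among the measured compounds shown here, the one measured step, a step that the two limits leave unreadable from compound 1 to compound 2, therefore cannot be read; both of its ends are limits. For the measured compounds named here, the only evidence on the measured values is the limit of > 100000 nM in this assay, at which 2 of the 2 values shown sit.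

Compound 3 `COC(=N)c1cn(COCCO)c2ncnc(N)c12` differs from compound 2 by a group of 4 heavy atoms (2 carbon, 1 nitrogen, 1 oxygen; no ring) in place of a group of 4 heavy atoms (1 carbon, 2 nitrogen, 1 oxygen; no ring), on an aromatic carbon. Going by the values given here, no measured step speaks to this change directly; the step between compound 1 and compound 2 was a different change and is unreadable in any case. Among the compounds with values here, with both measured compounds at the limit and no step of readable size, there is no ground to expect compound 3 to move beyond the scatter in this assay. Compound 3 is therefore expected to give about 150000 nM, with a range from 50000 nM to 500000 nM, most likely reported again as a limit. The expected step that the limit leaves unreadable from compound 2 to compound 3 is estimated to lie within the scatter.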

Compound 3, half-maximal inhibitory concentration: > 100000 nM
Compound 3 was reported as a limit; the forecaster's own chance of this, stated with the estimate: 80%; the middle value lies beyond the limit too.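

Compound 3 gives > 100000 nM in this assay, which is a limit of the assay and not a number. Neither the step to compound 3 from compound 1 nor the step to it from compound 2 can be read, since both ends of each are limits. The compounds shown leave open whether the groups on the aromatic carbon differ at all in this read-out, as all that stands is this: the limit of > 100000 nM in this assay, at which 3 of the 3 values shown sit.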